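A Methyl-to-4-Methylphenyl Step on Compound 3

The source may hold more compounds than are shown below. What is called first, only, known or untested is meant among the compounds shown, and "the series" means these compounds.

Three compounds that share one core have been measured in a functional assay on MCF7 cells (Homo sapiens) for cytotoxicity, read by MTT assay, with a stated time of 24 h, tested at 16 ug/mL; a higher number here means a stronger effect of the compound at the concentration tested, a lower number a weaker effect:
compound 1 `Cn1c(-c2ccc(NC(=O)CCl)cc2)nc(-c2ccccc2)c1-c1ccccc1` gives 15.2%
compound 2 `Cn1nnnc1SCC(=O)Nc1ccc(-c2nc(-c3ccccc3)c(-c3ccccc3)n2C)cc1` gives 63.7%
compound 3 `CCN1CCN(CC(=O)Nc2ccc(-c3nc(-c4ccccc4)c(-c4ccccc4)n3C)cc2)CC1` gives 32.8%

Compound 3 stands second highest of the three: the step of a number 17.6 percentage points higher from compound 1 to compound 3 (beyond the scatter) lies beyond the scatter, as does a number 30.9 percentage points lower from compound 2 to compound 3 (beyond the scatter). Compound 4 `Cc1ccc(CN2CCN(CC(=O)Nc3ccc(-c4nc(-c5ccccc5)c(-c5ccccc5)n4C)cc3)CC2)cc1` differs from compound 3 in one place: 4-methylphenyl in place of methyl on a saturated chain carbon bound to an amine nitrogen in a ring. Among the measured compounds shown here, no measured step touches that position; all three measured steps alter the group on the saturated chain carbon bound to the carbonyl carbon, and the largest, a number 48.5 percentage points higher from compound 1 to compound 2 (beyond the scatter), shows that changes in that region can move the read-out considerably. With nothing comparable measured for the present change, the expected step of a number 5.2 percentage points higher from compound 3 to compound 4 (within the scatter) is small, within or barely beyond the scatter. Compound 4 is therefore estimated at 38%, ranging from 20% to 58%.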

Compound 4, a percentage reported as activity, at one concentration (the size of the read-out at that concentration, not a potency): 26%
The estimate for compound 4 lay 12 percentage points above the measured number, within the range that was stated.
By their numbers in this assay, from the lowest: compound 1; then compounds 4 and 3 (each within the scatter of the next); then compound 2.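

In this assay, the step at the saturated chain carbon bound to an amine nitrogen in a ring, a number 6.8 percentage points lower from compound 3 to compound 4 (within the scatter), shows that this position accepts a six-membered aromatic ring of carbon only without a change beyond the scatter. Each earlier step altered the group on the saturated chain carbon bound to a carbonyl carbon and lay beyond the scatter. No supporting evidence bears on this result. From the compounds shown here alone, whether an amine or a carboxylic acid on that aromatic ring would give the same outcome remains open.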